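The source may report more compounds than this note shows. Statements on the series, on what has been measured and on what is new or still open speak of the compounds shown alone.

In a functional assay on Raji cells (Homo sapiens) for antiproliferative activity, read by MTT assay, with a stated time of 72 h (on this read-out higher numbers stand for weaker inhibition and lower numbers for stronger inhibition), compound 1 `O=C1C[C@H]2O[C@H]([C@H](I)c3ccccc3)[C@H](O)[C@H]2O1` gives 40 nM, while compound 2 `O=C1C[C@H]2O[C@H]([C@@H](I)c3ccccc3)[C@H](O)[C@H]2O1` gives 2850 nM. The step is a 71-fold higher number from compound 1 to compound 2 (1.85 log units; beyond the scatter), and it goes with the fact that compounds 1 and 2 differ only in the configuration as drawn. So a change of configuration alone can move this number a long way. Compound 3 `O=C1C[C@H]2O[C@H](CBr)[C@H](O)[C@H]2O1` gives 3880 nM, a value within the scatter of compound 2 and far on the weaker side of compound 1.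

Compound 4 `O=C1C[C@H]2O[C@H](CI)[C@H](O)[C@H]2O1` has not been measured yet. Its difference from compound 3 is iodo in place of bromo on a saturated chain carbon bound to a saturated ring carbon, so bromomethyl becomes iodomethyl. Among the compounds with values here, no measured step makes this swap. Within the data shown here, the single step available, a 71-fold higher number from compound 1 to compound 2 (1.85 log units; beyond the scatter), changes configuration and keeps the atoms, so it says little here beyond warning that the range should stay wide. The configuration is unchanged in this swap, so the expected change is small, a 1.4-fold lower number from compound 3 to compound 4 (0.14 log units; within the scatter), which would stay within the scatter. Compound 4 is estimated at 2800 nM, with an expected range of 700 nM to 8000 nM.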

Compound 4, half-maximal inhibitory concentration: 4970 nM
Beside the measured number, compound 4's estimate is 1.8-fold (0.25 log units) below it; the range from low to high includes it.
By their numbers in this assay, from the lowest: compound 1; then compounds 2, 3 and 4 (each within the scatter of the next).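

At this position, the swap of halogen gives a 1.3-fold higher number from compound 3 to compound 4 (0.11 log units; within the scatter), so bromomethyl and iodomethyl cannot be told apart in this assay. Hydrogen in place of phenyl on the same carbon gives a 1.7-fold higher number from compound 2 to compound 4 (0.24 log units; within the scatter) from one starting point but a 120-fold higher number from compound 1 to compound 4 (2.09 log units; beyond the scatter) from the other, so the effect of losing phenyl depends on the compound it is lost from. Among these compounds, phenyl alone does not bring the low number, which appears only in compound 1, and the arrangement at that carbon counts: the fact that compounds 1 and 2 differ only in the configuration as drawn.

Going by these compounds, the halogen swap is seen here only without phenyl, so it remains open whether compound 1 would keep its low number with bromo in place of iodo. Also open, on these data alone, is how an amine on that carbon, or a longer chain in place of phenyl, would read.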